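This account rests on a few compounds, and the source may have more. Where it says the series, first, only, none or still open, it means among the compounds named here.

Of the compounds shown here, three built on one shared core have been tested in a functional assay on Caco-2 cells (Homo sapiens) for antiproliferative activity, read by MTT assay; on this read-out higher numbers stand for weaker inhibition and lower numbers for stronger inhibition. Compound 1 `NS(=O)(=O)c1ccc(/N=C2\NC(=O)/C(=C3/C(=O)Nc4ccc(Br)cc43)S2)cc1` gives 42300 nM. Compound 2 `NS(=O)(=O)c1ccc(/N=C2\NC(=O)/C(=C3/C(=O)Nc4ccc([N+](=O)[O-])cc43)S2)cc1` gives 13800 nM; the step of a 3.1-fold lower number from compound 1 to compound 2 (0.49 log units; beyond the scatter) shows how much a nitro in place of bromo on an aromatic carbon moved the read-out. Compound 3 `Cc1ccc2c(c1)/C(=C1/S/C(=N/c3ccc(S(N)(=O)=O)cc3)NC1=O)C(=O)N2` gives 174000 nM, the highest of the three numbers, and so the weakest inhibition seen; its distance from the others is told by a 4.1-fold higher number from compound 1 to compound 3 (0.61 log units; beyond the scatter) and by a 13-fold higher number from compound 2 to compound 3 (1.10 log units; beyond the scatter).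

Compound 4 `COc1ccc2c(c1)/C(=C1/S/C(=N/c3ccc(S(N)(=O)=O)cc3)NC1=O)C(=O)N2` is not yet measured. It differs from compound 3 by methoxy in place of methyl on an aromatic carbon. Within the data shown here, none of the measured steps exchanges a methyl for a methoxy, so there is no direct precedent. What the steps do show is that swapping the group on this aromatic carbon can shift the number by a modest to large amount, as in a 4.1-fold higher number from compound 1 to compound 3 (0.61 log units; beyond the scatter) and a 13-fold higher number from compound 2 to compound 3 (1.10 log units; beyond the scatter), whereas methyl and methoxy differ by only one counted oxygen atom and one hydrogen-bond acceptor. A change no larger than modest, with the direction open, is therefore the expectation. Compound 4 is estimated at 120000 nM, within a range of 40000 nM to 360000 nM, which means an expected step of a 1.5-fold lower number from compound 3 to compound 4 (0.16 log units; within the scatter).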

Compound 4, half-maximal inhibitory concentration: 98300 nM
Estimate against measurement, compound 4: 1.2-fold (0.09 log units) above; the range from low to high includes it.
By their numbers in this assay, from the lowest: compound 2; then compound 1; then compounds 4 and 3 (each within the scatter of the next).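

In this assay, among these compounds, methoxy in place of methyl is the first exchange at this aromatic carbon that stays within the scatter (a 1.8-fold lower number from compound 3 to compound 4 (0.25 log units; within the scatter)), so adding the oxygen and its one hydrogen-bond acceptor gives no readable change here, unlike the earlier exchanges at this carbon. Compound 4 is nevertheless clearly separated from the two remaining compounds (a 7.1-fold higher number from compound 2 to compound 4 (0.85 log units; beyond the scatter); a 2.3-fold higher number from compound 1 to compound 4 (0.37 log units; beyond the scatter)), which places the four groups in three tiers: nitro in compound 2 gives the strongest inhibition, bromo in compound 1 comes next, and methoxy in compound 4 and methyl in compound 3 sit together with the highest numbers. No measured property of these compounds is available to explain this ranking.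

From the compounds shown here alone, with only four groups at this one carbon, it remains open how an amine, a carboxylic acid or a longer chain such as ethoxy would fall within these tiers. Going by these compounds, it is also open whether any other group could give a lower number than nitro, and whether this ranking would hold with a change elsewhere on the shared core.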